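The compounds below may be only part of what the source reports. "The series", "measured", "known", "first", "only" and "open" are said of these compounds alone.

Measured so far:
compound 1 `Cc1c2c(n3c1CCCNC(=O)C[C@H](C)Nc1cc-3ccc1C(N)=O)CC(C)(C)CC2=O`: 3330 nM
compound 2 `CC(=O)NCCN1CC[C@H](C)Nc2cc(ccc2C(N)=O)-n2c(c(C)c3c2CC(C)(C)CC3=O)CC1=O`: > 5000 nM
compound 3 `Cc1c2c(n3c1CCN(C(=O)[C@@H](C)N)CC[C@H](C)Nc1cc-3ccc1C(N)=O)CC(C)(C)CC2=O`: 710 nM

In a functional assay on HCT-116 cells (Homo sapiens) for antiproliferative activity (on this read-out higher numbers stand for an effect only at larger amounts of compound and lower numbers for an effect already at smaller amounts), compound 1 gives 3330 nM and compound 3 gives 710 nM. For compound 2 the result is only a limit, > 5000 nM, and not a number. That is the limit of > 5000 nM in this assay, at which 1 of the 3 values shown sits, so compound 2 stands at the edge of the numbers shown. Compound 4 `Cc1c2c(n3c1CC(=O)N(C)CC[C@H](C)Nc1cc-3ccc1C(N)=O)CC(C)(C)CC2=O` has not been measured. It differs from compound 2 by hydrogen in place of acetamidomethyl on a saturated chain carbon bound to an amide-type nitrogen in a ring. Among the compounds with values here, no measured pair shows a step of this kind, so the size of the step is uncertain. The step is expected to be modest an at least 1.6-fold lower number from compound 2 to compound 4 (0.22 log units; that floor lies within the scatter), toward an effect at smaller amounts. In this assay compound 4 is estimated at 3000 nM, within 800 nM to 12000 nM.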

Compound 4, half-maximal effective concentration: 247 nM
Estimate against measurement, compound 4: 12-fold (1.08 log units) above, outside the stated range (below it).
By their numbers in this assay, from the lowest: compound 4; then compound 3; then compound 1. At a limit, above all of these: compound 2.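

In this assay, hydrogen in place of acetamidomethyl on a saturated chain carbon bound to an amide-type nitrogen in a ring gives an at least 20-fold lower number from compound 2 to compound 4 (1.30 log units; beyond the scatter). Within the data shown here, this is the first single-place comparison here, and it shows that what this position carries matters greatly. For compound 2 the result is a limit and not a number, which makes the step a floor: the limit of > 5000 nM in this assay, at which 1 of the 4 values shown sits.

Only these two groups appear at this place. As far as these compounds go, whether an aminomethyl group or a carboxylic acid would be tolerated here remains open.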